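Dimethoxy to chloro swap on the benzylamine arm

A few compounds are considered here, and "the series" means these few. Any claim that something is new, unique, unknown or untested is made for them only; others in the source may bear on it.

Measured so far:
Compound 1 `CC(C)(C)c1ccc(CNCCNS(=O)(=O)c2cc(C(F)(F)F)cc(C(F)(F)F)c2)cc1` gives 8800 nM in a functional assay on BXPC-3 cells (Homo sapiens) for inhibition, read by MTT assay, with a stated time of 72 h; a higher number here means a weaker inhibitor of growth, a lower number a stronger inhibitor of growth.
Compound 2 `O=S(=O)(NCCCNCc1ccc(Cl)cc1)c1cc(C(F)(F)F)cc(C(F)(F)F)c1` gives 1600 nM in this assay.
Compound 3 `COc1ccc(CNCCCNS(=O)(=O)c2cc(C(F)(F)F)cc(C(F)(F)F)c2)cc1OC` gives 13000 nM in this assay.

Compound 3 carries the highest number of the three, though its gap to compound 1 lies within the scatter, so no order between those two can be claimed; only compound 2 sits clearly apart, with an 8.1-fold higher number from compound 2 to compound 3 (0.91 log units; beyond the scatter).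

Compound 4 `O=S(=O)(NCCCNCc1cccc(Cl)c1)c1cc(C(F)(F)F)cc(C(F)(F)F)c1` differs from compound 3 by 3-chlorophenyl in place of 3,4-dimethoxyphenyl on a saturated chain carbon bound to an amine nitrogen. Within the data shown here, the one step that bears on this is the move from compound 2 to compound 3, an 8.1-fold higher number from compound 2 to compound 3 (0.91 log units; beyond the scatter), which is close to the reverse of the present change, except that the chlorine now sits on a 3-chlorophenyl rather than a 4-chlorophenyl. Among the measured compounds shown here, no measured pair separates those two chlorophenyl positions, so the expectation rests on the dimethoxy-to-chloro exchange alone. The number for compound 4 is therefore expected to fall, roughly undoing the earlier rise, giving a 5.2-fold lower number from compound 3 to compound 4 (0.72 log units; beyond the scatter). Compound 4 is estimated at 2500 nM, within 1000 nM to 7000 nM.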

Compound 4, concentration for 50% growth inhibition: 3800 nM
Estimate against measurement, compound 4: 1.5-fold (0.18 log units) below; low and high end bracket the measured number.
By their numbers in this assay, from the lowest: compound 2; then compound 4; then compounds 1 and 3 (each within the scatter of the next).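

Within this assay the change from 3,4-dimethoxyphenyl to 3-chlorophenyl on a saturated chain carbon bound to an amine nitrogen lowers the number (a 3.4-fold lower number from compound 3 to compound 4 (0.53 log units; beyond the scatter)), so the gap between dimethoxy and chloro seen earlier with 4-chlorophenyl is not confined to that one chlorophenyl. Among these compounds, the placing of the chlorine also counts at this position, which the earlier compounds could not show: moving to 3-chlorophenyl raises the number (a 2.4-fold higher number from compound 2 to compound 4 (0.38 log units; beyond the scatter)), leaving 4-chlorophenyl with the lower number of the pair. Nothing measured here accounts for either step.

Open, from the compounds shown here alone, is how an unsubstituted phenyl or a bromophenyl would sit against these two chlorophenyl groups. Also open, going by these compounds, is whether the same order of groups holds on the chain of compound 1.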